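From ethoxy to methoxy: estimating compound 3

The source may hold more compounds than are shown below. What is called first, only, known or untested is meant among the compounds shown, and "the series" means these compounds.

Measured in a functional assay on A549 cells (Homo sapiens) for antiproliferative activity, read by MTT assay, with a stated time of 48 h (a lower number here means a stronger inhibitor, a higher number a weaker inhibitor), so far
Compound 1 (`COc1cc(-c2nnc3c(OC)cc(-c4ccc5[nH]ccc5c4)cn23)cc(OC)c1OC`) gives 167 nM
Compound 2 (`CCOc1cc(-c2ccc3c(ccn3C)c2)cn2c(-c3cc(OC)c(OC)c(OC)c3)nnc12`) gives 334 nM

In this assay compound 2 stands at 334 nM and compound 1 at 167 nM, two values within the usual scatter of each other, so the numbers do not separate them.

Compound 3 (`COc1cc(-c2nnc3c(OC)cc(-c4ccc5c(ccn5C)c4)cn23)cc(OC)c1OC`) has not yet been measured. It differs from compound 2 in one place (hydrogen in place of methyl on a saturated chain carbon bound to an oxygen on an aromatic ring), with hydrogen in place of methyl on a saturated chain carbon bound to an oxygen on an aromatic ring, which reads as ethoxy to methoxy. Within the data shown here, no pair of measured compounds shows this change alone, so the data give no direct size for it.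

The expectation in this assay is therefore for no step beyond the scatter, with at most a slight lean toward a lower number. The expected step of a 1.9-fold lower number from compound 2 to compound 3 (0.27 log units; within the scatter) rests on compound 2 at 334 nM and compound 1 at 167 nM, which stand close together. For compound 3 the estimate is 180 nM, with an expected range from 50 nM to 550 nM.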

Compound 3, half-maximal inhibitory concentration: 69 nM
The estimate for compound 3 lay 2.6-fold (0.42 log units) above the measured number; low and high end bracket the measured number.
By their numbers in this assay, from the lowest: compound 3; then compounds 1 and 2 (each within the scatter of the next).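

In this assay, ethoxy to methoxy on a saturated chain carbon bound to an oxygen on an aromatic ring can now be read alone, and it gives a 4.8-fold lower number from compound 2 to compound 3 (0.68 log units; beyond the scatter), which shows that the number at this position responds to the loss of a single methyl. Compound 3 also opens a second single-place comparison, methyl in place of hydrogen on an aromatic nitrogen, which gives a 2.4-fold lower number from compound 1 to compound 3 (0.38 log units; beyond the scatter), so with methoxy held constant this methyl goes with a lower number, and compound 3 has the lowest number of the three. Nothing available explains either step.

Each change is seen only once, on one background, so the compounds shown cannot tell whether ethoxy to methoxy would give a similar step with hydrogen on the aromatic nitrogen. They also leave open how this position would respond to a hydroxyl group, a propoxy chain or a longer chain, and so whether the trend with chain length continues beyond these two groups.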